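Methyl in Place of Hydrogen on the Oxygen of Compound 2

The source may hold more compounds than are shown below. What is called first, only, known or untested is meant among the compounds shown, and "the series" means these compounds.

Measured compounds in a functional assay on HT-29 cells (Homo sapiens) for inhibition, read by sulforhodamine B assay, with a stated time of 48 h, tested at 0.01 uM; a higher number here means a weaker effect of the compound at the concentration tested, a lower number a stronger effect:
compound 1 `O=C(Nc1cccc(-n2cc(-c3ccncc3)c(-c3cc(O)cc(Cl)c3)n2)c1)Nc1ccc(Cl)c(C(F)(F)F)c1` gives 98%
compound 2 `O=C(Nc1cccc(-n2cc(-c3ccncc3)c(-c3cc(O)cc(Cl)c3)n2)c1)Nc1ccc(Cl)c(Cl)c1` gives 91%
compound 3 `COc1cc(Cl)cc(-c2nn(-c3cccc(NC(=O)Nc4cc(C(F)(F)F)cc(C(F)(F)F)c4)c3)cc2-c2ccncc2)c1` gives 102%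

Compound 2 has the lowest of the three numbers; compound 1 stands within the scatter of it, compound 3 beyond it. Compound 4 `COc1cc(Cl)cc(-c2nn(-c3cccc(NC(=O)Nc4ccc(Cl)c(Cl)c4)c3)cc2-c2ccncc2)c1` differs from compound 2 by one change: methyl in place of hydrogen on an oxygen on an aromatic ring. Among the measured compounds shown here, no measured step touches this oxygen. For the measured compounds named here, the only measured step, a number 7 percentage points lower from compound 1 to compound 2 (within the scatter), is a chloro in place of trifluoromethyl on an aromatic carbon and says nothing about the methoxy. Compound 3 carries the methoxy but also differs from compound 1 elsewhere, so only its value and that of compound 2 can be set side by side. All three numbers lie near full activity, so in this assay compound 4 is expected to show no step beyond the scatter, an estimated a number 5 percentage points higher from compound 2 to compound 4 (within the scatter), giving 96% within 85% to 106%.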

Compound 4, a percentage reported as activity, at one concentration (the size of the read-out at that concentration, not a potency): 103%
Beside the measured number, compound 4's estimate is 7 percentage points below it; measured number inside the range.
By their numbers in this assay, from the lowest: compounds 2, 1, 3 and 4 (each within the scatter of the next, the first and the last beyond it).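

In this assay, among the compounds shown here, methyl in place of hydrogen on the oxygen gives a number 12 percentage points higher from compound 2 to compound 4 (beyond the scatter) and so provides the first measured step at this position. The step is modest, but it shows that this oxygen is not silent in the assay: with the rest of the structure unchanged, the hydroxy form has the stronger effect at the concentration tested. No evidence shown accounts for this difference.

The compounds shown leave open how an amine or a carboxylic acid in place of the hydroxy would read, and whether an ethyl or longer chain on the oxygen would go further than methyl.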